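Furan-2-yl for pyridin-2-yl on the pyrazole-like sulfonyl ester series

The source may hold more compounds than are shown below. What is called first, only, known or untested is meant among the compounds shown, and "the series" means these compounds.

Measured compounds:
compound 1 `CCc1ccc(-c2cc(C)n(S(=O)(=O)Oc3ccccc3)n2)cc1` gives 21.1%
compound 2 `Cc1cccc(-c2cc(C)n(S(=O)(=O)Oc3ccccc3)n2)c1` gives 8.7%
compound 3 `Cc1cc(-c2ccccn2)nn1S(=O)(=O)Oc1ccccc1` gives 11.3%

Of the compounds shown here, three have been measured in a functional assay on the whole organism for inhibition, with Mus musculus as the target, with stated times of 3 days and 30 min, at a dose of 30 mg/kg by the oral route; on this read-out higher numbers stand for more inhibition at the one dose given (going by the name of the read-out) and lower numbers for less inhibition. They share a core and differ only in the aromatic group on one carbon of that core. Compound 3 sits among the three with its number falling within the scatter of both others: its nearest neighbour is compound 2, a number 2.6 percentage points higher from compound 2 to compound 3 (within the scatter), and the furthest is compound 1, a number 9.8 percentage points lower from compound 1 to compound 3 (within the scatter). For the measured compounds named here, the one step that reaches beyond the scatter is a number 12.4 percentage points lower from compound 1 to compound 2 (beyond the scatter).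

Compound 4 `Cc1cc(-c2ccco2)nn1S(=O)(=O)Oc1ccccc1` is the next compound and has not yet been measured. Its relation to compound 3 is furan-2-yl in place of pyridin-2-yl on an aromatic carbon.

Going by the values given here, the steps that bear on this change are those that also swap the aromatic group at this carbon: from compound 1 to compound 3 and from compound 2 to compound 3, both within the scatter. Neither involves a five-membered ring, so the data give no direct guide. Compound 4 is therefore expected to show a step of about a number 0.3 percentage points lower from compound 3 to compound 4 (within the scatter) in this assay, that is none beyond the scatter. The estimate for compound 4 is 11%, expected to fall between 2% and 22%.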

Compound 4, a percentage reported as inhibition, in the whole organism at one dose (the size of the read-out at that dose, not a potency): 12.5%
Compound 4: middle estimate off by 1.5 percentage points, on the low side, within the range that was stated.
By their numbers in this assay, from the lowest: compounds 2, 3, 4 and 1 (each within the scatter of the next, the first and the last beyond it).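

In this assay, a five-membered aromatic ring can stand on this aromatic carbon in place of a six-membered one, and the exchange of pyridin-2-yl for furan-2-yl gives a number 1.2 percentage points higher from compound 3 to compound 4 (within the scatter), so neither the change of ring size nor the change of hetero atom from nitrogen to oxygen leaves a readable mark here. For the compounds shown here, compound 4 is also not separated from either compound that carries a substituted phenyl group, with a number 3.8 percentage points higher from compound 2 to compound 4 (within the scatter) and a number 8.6 percentage points lower from compound 1 to compound 4 (within the scatter), so the new compound adds a second heteroaromatic group that cannot be told apart from any of the others, and the only step beyond the scatter remains a number 12.4 percentage points lower from compound 1 to compound 2 (beyond the scatter). There is no measurement on hand that would explain any of these numbers.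

Going by these compounds, it remains open whether anything other than an aromatic ring on this carbon, such as a longer alkyl chain, would give a number beyond the scatter of this series. Also open, on these data alone, is whether an amine or a carboxylic acid carried on the aromatic ring at this carbon would move the number away from those of compound 3 and compound 4.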